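A few compounds are considered here, and "the series" means these few. Any claim that something is new, unique, unknown or untested is made for them only; others in the source may bear on it.

Among the measured compounds shown here, compound 3 `COc1ncnc2c1c(-c1cc3ccccc3o1)cn2[C@@H]1O[C@H](CO)[C@@H](O)[C@H]1O` is the only member of the set with a number in a functional assay on HCT-116 cells (Homo sapiens), read by MTT assay, with a stated time of 72 h; on this read-out higher numbers stand for weaker inhibition and lower numbers for stronger inhibition: compound 3 gives 14500 nM. Compound 1 `CN(C)c1ncnc2c1c(-c1cc3ccccc3o1)cn2[C@@H]1O[C@H](CO)[C@@H](O)[C@H]1O` reaches only a limit of this assay, > 20000 nM. Compound 2 `CNc1ncnc2c1c(-c1ccoc1)cn2[C@@H]1O[C@H](CO)[C@@H](O)[C@H]1O` likewise stops at a limit, > 20000 nM. For the measured compounds named here, the one single-place step measured, an at least 1.3-fold lower number from compound 1 to compound 3 (0.13 log units; that floor lies within the scatter), shows methoxy in place of dimethylamino on an aromatic carbon bringing the number into the measurable range by a margin that the scatter cannot separate from zero. Compound 4 `CNc1ncnc2c1c(-c1cc3ccccc3o1)cn2[C@@H]1O[C@H](CO)[C@@H](O)[C@H]1O` differs from compound 3 by methylamino in place of methoxy on an aromatic carbon. Going by the values given here, compound 2 also carries methylamino, but its aryl group differs, so no single-place step connects it to compound 4. Because two of the three values sit at the limit of > 20000 nM in this assay, at which 2 of the 3 values shown sit, the working assumption is that this series sits near the floor of this assay, and the change in compound 4 is not expected to move it beyond the scatter. Compound 4 is therefore estimated at 18000 nM, within 6000 nM to 50000 nM, a step of a 1.2-fold higher number from compound 3 to compound 4 (0.09 log units; within the scatter) that is itself within the scatter.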

Compound 4, half-maximal inhibitory concentration: > 20000 nM
Compound 4: no number, only a limit; the forecaster's own chance of this, stated with the estimate: 55%; at least 1.1-fold (0.04 log units) between middle value and limit.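

At the aromatic carbon next to the ring nitrogen, with the 1-benzofuran-2-yl group kept, methylamino in place of methoxy gives an at least 1.3-fold higher number from compound 3 to compound 4 (0.13 log units; that floor lies within the scatter) in this assay. Among the compounds shown here, compound 4 gives only a limit, as compound 1 does, so methoxy in compound 3 remains the only group at this position with a number, and the data do not separate it from methylamino or dimethylamino. The steps from compound 2 and from compound 1 to compound 4 cannot be read, and the set now rests largely at one boundary: the limit of > 20000 nM in this assay, at which 3 of the 4 values shown sit.

Going by these compounds, it remains open whether another group on this carbon, such as ethoxy, chlorine or methyl, would move the number beyond the scatter from compound 3. On these data alone, the true values of compound 1 and compound 4 also remain open, so any difference between methylamino and dimethylamino is unresolved.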